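The source may report more compounds than this note shows. Statements on the series, on what has been measured and on what is new or still open speak of the compounds shown alone.

Working notes on the series.

Compound 1 `O=C1N=C(N2N=C(c3ccccc3)CC2c2ccccc2O)S/C1=C1/C(=O)Nc2ccccc21` and compound 2 `O=C1N=C(N2N=C(c3ccccc3)CC2c2ccccc2O)S/C1=C1/C(=O)Nc2ccc(Br)cc21` share one core; compound 3 `COc1ccc(C2=NN(C3=NC(=O)/C(=C4\C(=O)Nc5ccccc54)S3)C(c3ccc(Cl)cc3)C2)cc1` and compound 4 `COc1ccc(C2=NN(C3=NC(=O)/C(=C4\C(=O)Nc5ccc(Br)cc54)S3)C(c3ccc(Cl)cc3)C2)cc1` share another. How the two cores differ is not broken down here. In a functional assay on cells (Cancer cell lines, Homo sapiens) for cytotoxicity, read by sulforhodamine B assay, with a stated time of 48 h (a higher number here means a weaker inhibitor of growth, a lower number a stronger inhibitor of growth), compound 1 gives 4220 nM, compound 2 gives 460 nM, and compound 3 gives 100000 nM, the highest number of the three measured.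

The change bromo in place of hydrogen on an aromatic carbon produced the step of a 9.2-fold lower number from compound 1 to compound 2 (0.96 log units; beyond the scatter). The change bromo in place of hydrogen on an aromatic carbon is the same change made on the other core. Compound 4 is not yet measured in this assay. Among the compounds with values here, only one earlier instance is available, and it sits on a different core, so a step of similar direction but uncertain size is expected. The step of a 6.7-fold lower number from compound 3 to compound 4 (0.82 log units; beyond the scatter) is estimated for compound 4, resting on the measured step from compound 1 to compound 2. Compound 4 is expected to give about 15000 nM, with a range from 4000 nM to 60000 nM.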

Compound 4, concentration for total growth inhibition: 7440 nM
For compound 4 the middle estimate is 2.0-fold (0.30 log units) above the measured one; measured number inside the range.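

In this assay, bromo in place of hydrogen on an aromatic carbon gives a 13-fold lower number from compound 3 to compound 4 (1.13 log units; beyond the scatter) on the core of compound 3, so the change carries over to this second core with the same direction. The size also holds across the two cores: the same change on two cores in this assay, a 9.2-fold lower number (0.96 log units; beyond the scatter) from compound 1 to compound 2 and a 13-fold lower number (1.13 log units; beyond the scatter) from compound 3 to compound 4, 1.5-fold (0.17 log units) apart, within the scatter of two such steps.
This is one change at one place on two cores, so it does not show that the step would hold on any other core, and it gives no reason for the step.

The compounds shown leave open whether an amine or a carboxylic acid on the same aromatic carbon would lower the number as bromo does. They also leave open how much each difference between the two cores contributes on its own.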